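This account rests on a few compounds, and the source may have more. Where it says the series, first, only, none or still open, it means among the compounds named here.

Working notes on the series. Among the compounds with values here, compound 3 `CC(=O)Nc1cc(NC(=O)NCCCCC(c2ccc(F)cc2)c2ccc(F)cc2)ccc1Cl` gives 609 nM in an ADME assay on isolated protein for inhibition of sodium-dependent dopamine transporter (Homo sapiens) (on this read-out higher numbers stand for weaker inhibition and lower numbers for stronger inhibition), the highest number of the three measured so far. Compound 1 `O=C(NCCCCC(c1ccc(F)cc1)c1ccc(F)cc1)Nc1ccc(Cl)cc1` gives 15 nM in this assay, and compound 2 `O=C(NCCCCC(c1ccc(F)cc1)c1ccc(F)cc1)Nc1ccc(Cl)c(C(F)(F)F)c1` gives 6.5 nM. The step of a 41-fold higher number from compound 1 to compound 3 (1.61 log units; beyond the scatter) is large, as is a 94-fold higher number from compound 2 to compound 3 (1.97 log units; beyond the scatter); the step of a 2.3-fold lower number from compound 1 to compound 2 (0.36 log units; beyond the scatter) is modest.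

Compound 4 `Cc1ccc(NC(=O)NCCCCC(c2ccc(F)cc2)c2ccc(F)cc2)cc1C` is not yet measured. It differs from compound 3 in one place: 3,4-dimethylphenyl in place of 3-acetamido-4-chlorophenyl on an amide-type nitrogen. Within the data shown here, the steps that bear on this change are the two that introduce the acetamido group, a 41-fold higher number from compound 1 to compound 3 (1.61 log units; beyond the scatter) and a 94-fold higher number from compound 2 to compound 3 (1.97 log units; beyond the scatter), since compound 4 leaves that group out again; both of them went toward higher numbers by a large margin. Among the measured compounds shown here, no measured step sets the two methyl groups against hydrogen or against trifluoromethyl on that aromatic ring, so the size of their own contribution is unknown, and the expectation rests on the loss of the acetamido group as seen in those two steps.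

A large step toward lower numbers is therefore expected in this assay, of about a 41-fold lower number from compound 3 to compound 4 (1.61 log units; beyond the scatter). Compound 4 is estimated at 15 nM, with a range of 4 nM to 60 nM.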

Compound 4, inhibition constant: 80 nM
Estimate against measurement, compound 4: 5.3-fold (0.73 log units) below, outside the stated range (above it).
By their numbers in this assay, from the lowest: compound 2; then compound 1; then compound 4; then compound 3.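

In this assay, 3,4-dimethylphenyl in place of 3-acetamido-4-chlorophenyl on the amide-type nitrogen gives a 7.6-fold lower number from compound 3 to compound 4 (0.88 log units; beyond the scatter), so the higher number of compound 3 does not disappear once the acetamido group and the chlorine have gone. The two other comparisons show that a ring without acetamido can still sit well above the chlorinated rings: a 5.3-fold higher number from compound 1 to compound 4 (0.73 log units; beyond the scatter) and a 12-fold higher number from compound 2 to compound 4 (1.09 log units; beyond the scatter), which places compound 4 between those two compounds and compound 3, and so shows that the group on this nitrogen matters beyond the presence or absence of acetamido. Nothing available explains the gaps among these four aryl groups.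

The compounds shown leave open how the difference between compound 1 and compound 4 divides between the missing chlorine and the two methyl groups, as these changes occur together and a ring bearing a single methyl group would be needed to separate them. They also leave open how this position responds to a methoxy group, a nitrile, an amine or a carboxylic acid on the same aromatic ring.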